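Taking the Chloro Off Compound 2

The source may report more compounds than this note shows. Statements on the series, on what has been measured and on what is new or still open speak of the compounds shown alone.

The measurements come from an assay on isolated protein for activation of Nicotinamide phosphoribosyltransferase (Homo sapiens); a higher number here means that more compound is needed for the effect, a lower number that less compound is needed. Compound 1 `CCOC(=O)c1ccc(NC(=O)NCc2cc[nH]n2)cc1` gives 69000 nM in this assay. Compound 3 `CCOC(=O)c1ccc(NC(=O)N(C)Cc2ccncc2)cc1` reaches only the limit of this assay, > 100000 nM, which is not a number but the edge of what the assay reports. Compound 2 `O=C(NCc1ccncc1)Nc1ccc(S(=O)(=O)c2cccc(Cl)c2)cc1` gives 69 nM, the lowest of the two numbers in hand; compound 1 stands far above it, well beyond the scatter of repeated measurements.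

Compound 4 `O=C(NCc1ccncc1)Nc1ccc(S(=O)(=O)c2ccccc2)cc1` has not yet been measured. It differs from compound 2 in one place: hydrogen in place of chloro on an aromatic carbon. For the measured compounds named here, no pair of measured compounds shows this kind of change, so its effect in this assay has to be guessed from the single point of compound 2. A chloro is a small group, and its removal is expected to give a modest step at most, likely a small rise in the number, though a step within the scatter would not surprise. The value of compound 4 is estimated at 130 nM, with a range from 40 nM to 450 nM, which means an expected step of a 1.9-fold higher number from compound 2 to compound 4 (0.28 log units; within the scatter).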

Compound 4, half-maximal effective concentration: 85 nM
The estimate for compound 4 lay 1.5-fold (0.18 log units) above the measured number; the measured number falls inside the stated range.
By their numbers in this assay, from the lowest: compounds 2 and 4 (each within the scatter of the next); then compound 1. At a limit, above all of these: compound 3.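

In this assay, hydrogen in place of chloro on this aromatic carbon, the change from 3-chlorophenyl to phenyl, gives a 1.2-fold higher number from compound 2 to compound 4 (0.09 log units; within the scatter) and so leaves the number where it was. For the compounds shown here, the earlier compounds offered no pair differing in one place, so this is the only direct reading of this position, and it shows that the chloro is not needed for a number of this size. Nothing measured here bears on why the two compounds read alike.

As far as these compounds go, whether this position tolerates everything or only these two small substituents stays open, since a larger or charged group on the same carbon, such as a methoxy, an amine or a carboxylic acid, could behave quite differently. From the compounds shown here alone, the other carbons of this ring also remain unexplored, so the reading holds for this one place only.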